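The source may hold more compounds than are shown below. What is called first, only, known or untested is meant among the compounds shown, and "the series" means these compounds.

Compound 1 `CC1CCN(c2nc(C(F)(F)F)ccc2CNC(=O)Nc2cccc3c(=O)[nH]ccc23)CC1` gives 9.59 nM.
Compound 2 `CC1CCN(c2nc(C(F)(F)F)ccc2CNC(=O)Nc2cccc3cc[nH]c(=O)c23)CC1` gives "not active" (no number reported).

For the measured compounds named here, in an assay on CHO cells for agonist activity at transient receptor potential cation channel subfamily V member 1 (Homo sapiens) (on this read-out higher numbers stand for an effect only at larger amounts of compound and lower numbers for an effect already at smaller amounts), compound 1 gives 9.59 nM and is the only compound with a number; compound 2 gives "not active" (no number reported) there. Compound 3 `O=C(NCc1ccc(C(F)(F)F)nc1SC1CCCCC1)Nc1cccc2c(=O)[nH]ccc12` keeps the shared core of compound 1 and changes one group: cyclohexylsulfanyl in place of 4-methylpiperidin-1-yl on an aromatic carbon. Going by the values given here, no measured pair tells how such a swap moves this assay. The ring that enters has no nitrogen in it, so a loss beyond the usual scatter is expected, but a small one. Compound 3 is therefore expected to give 30 nM, likely between 6 nM and 150 nM, a step of a 3.1-fold higher number from compound 1 to compound 3 (0.50 log units; beyond the scatter).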

Compound 3, half-maximal effective concentration: 69.3 nM
For compound 3 the middle estimate is 2.3-fold (0.36 log units) below the measured one; the range from low to high includes it.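

In this assay the change to cyclohexylsulfanyl brings a 7.2-fold higher number from compound 1 to compound 3 (0.86 log units; beyond the scatter) on this aromatic carbon next to the ring nitrogen. The loss lies beyond the usual scatter, yet compound 3 still gives a number, so a ring of carbon only, attached through sulfur, is accepted at this position, while the 4-methylpiperidin-1-yl of compound 1 does better. From the compounds shown here alone, whether a morpholine ring, a phenyl ring or a plain amine here would give lower or higher numbers stays open. Nothing measured here explains the step.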